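The compounds below may be only part of what the source reports. "The series", "measured", "known", "first", "only" and "open" are said of these compounds alone.

Measured compounds:
- compound 1 `COc1ccc(Oc2ccc3c(NCCCNCc4cc(F)ccc4OC)ccnc3c2)cc1`: 7000 nM
- compound 2 `CC(C)(C)c1ccc(-c2ccc3c(NCCCNCc4ccco4)ccnc3c2)cc1`: 3150 nM

In an ADME assay on HepG2 cells (Homo sapiens) for cytotoxicity, read by luminescence, CellTiter-Glo and ATP content, with a stated time of 72 h (on this read-out higher numbers stand for an effect only at larger amounts of compound and lower numbers for an effect already at smaller amounts), compound 1 gives 7000 nM, the highest of the two numbers. Compound 2 gives 3150 nM, a lower number, and that gap lies beyond the usual scatter. Compound 3 `COc1ccc(F)cc1CNCCCNc1ccnc2cc(Oc3cccc(N(C)C)c3)ccc12` differs from compound 1 by 3-(dimethylamino)phenyl in place of 4-methoxyphenyl on an oxygen on an aromatic ring. Among the compounds with values here, no measured pair shows this change, so nothing here points to a step beyond the scatter in either direction, and a small step is expected. Compound 3 is therefore expected to give about 6000 nM in this assay, with a range from 2500 nM to 15000 nM. The step this estimate means is expected to be a 1.2-fold lower number from compound 1 to compound 3 (0.07 log units; within the scatter).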

Compound 3, half-maximal effective concentration: 3300 nM
Compound 3: middle estimate off by 1.8-fold (0.26 log units), on the high side, within the range that was stated.
By their numbers in this assay, from the lowest: compounds 2 and 3 (each within the scatter of the next); then compound 1.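

In this assay, within the data shown here, the change to 3-(dimethylamino)phenyl from 4-methoxyphenyl on this oxygen gives a 2.1-fold lower number from compound 1 to compound 3 (0.33 log units; beyond the scatter), the first one-place comparison here. It shows that the group at this position can move the number beyond ordinary repeat variation, although this rests on a single pair. Nothing available explains the shift.

From the compounds shown here alone, it remains open whether losing the methoxy group or gaining the dimethylamino group matters more. Going by these compounds, how a plain phenyl or a morpholine ring at this position would compare also remains open.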